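The compounds below may be only part of what the source reports. "The series", "measured", "known", "first", "only" and "open" are said of these compounds alone.

Measured so far:
Compound 1, `O=C1C(=O)N(CN2CCN(c3ccnc4cc(Cl)ccc34)CC2)c2ccccc21`: 71700 nM
Compound 2, `O=C1C(=O)N(CN2CCN(c3ccnc4cc(C(F)(F)F)ccc34)CC2)c2ccccc21`: 43900 nM
Compound 3, `NC(=S)N/N=C1/C(=O)N(CN2CCN(c3ccnc4cc(Cl)ccc34)CC2)c2cccc(Cl)c21`: 20700 nM

In an ADME assay on 184B5 cells (Homo sapiens) for cytotoxicity, read by sulforhodamine B assay, with a stated time of 48 h (on this read-out higher numbers stand for weaker inhibition of growth and lower numbers for stronger inhibition of growth), compound 1 gives 71700 nM and compound 2 gives 43900 nM. The two differ in one place, (trifluoromethyl in place of chloro on an aromatic carbon), and the step that this change made is a 1.6-fold lower number from compound 1 to compound 2 (0.21 log units; within the scatter). Compound 3 has a different core; how its core differs from that of compound 1 is not broken down here. In this assay compound 3 gives 20700 nM.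

Compound 4, `NC(=S)N/N=C1/C(=O)N(CN2CCN(c3ccnc4cc(C(F)(F)F)ccc34)CC2)c2cccc(Cl)c21`, differs from compound 3 by trifluoromethyl in place of chloro on an aromatic carbon, the same change as between compound 1 and compound 2, at the same place. Since that change made only a small step in this assay, shown by a 1.6-fold lower number from compound 1 to compound 2 (0.21 log units; within the scatter), a step of similar size is expected, a 1.6-fold lower number from compound 3 to compound 4 (0.20 log units; within the scatter). For compound 4 the estimated value is 13000 nM, expected to lie between 6000 nM and 30000 nM.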

Compound 4, concentration for 50% growth inhibition: 87800 nM
Estimate against measurement, compound 4: 6.8-fold (0.83 log units) below, outside the stated range (above it).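

In this assay, trifluoromethyl in place of chloro on an aromatic carbon gives a 4.2-fold higher number from compound 3 to compound 4 (0.63 log units; beyond the scatter), so the step seen on the core of compound 1 does not carry over to the core of compound 3: the same change on two cores in this assay, a 1.6-fold lower number (0.21 log units; within the scatter) from compound 1 to compound 2 and a 4.2-fold higher number (0.63 log units; beyond the scatter) from compound 3 to compound 4, 6.9-fold (0.84 log units) apart, beyond the scatter of two such steps. In this series, then, the step measured on one core is a poor guide to the same change on the other. The two cores differ in more than one place, and these two pairs do not show which difference matters or give a rule for other cores.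

From the compounds shown here alone, it remains open whether another group at this place, such as a nitrile or an amine, would also behave differently on the two cores. Also open, going by these compounds, is how the step would look on a core carrying only one of the differences between compound 1 and compound 3.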